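Thioether chain replacement on the shared core

The compounds below may be only part of what the source reports. "The series", "measured", "known", "first", "only" and "open" are said of these compounds alone.

Measured so far:
compound 1 `CC(C(=O)NCc1ccc(C(F)(F)F)nc1SCCCN1CCCCC1)c1ccc(NS(C)(=O)=O)c(F)c1` — 250 nM
compound 2 `CC1CCN(CCCSc2nc(C(F)(F)F)ccc2CNC(=O)C(C)c2ccc(NS(C)(=O)=O)c(F)c2)CC1` — 217 nM

Within the data shown here, in an assay on CHO-K1 cells for antagonist activity at transient receptor potential cation channel subfamily V member 1 (Homo sapiens), read by FLIPR (on this read-out higher numbers stand for weaker inhibition and lower numbers for stronger inhibition), compound 2 gives the lower of the two numbers, but the only step to it, a 1.2-fold lower number from compound 1 to compound 2 (0.06 log units; within the scatter), lies within the scatter, so the two compounds are not separated. Compound 3 `COC(=O)CCSc1nc(C(F)(F)F)ccc1CNC(=O)C(C)c1ccc(NS(C)(=O)=O)c(F)c1` differs from compound 2 by methoxycarbonyl in place of (4-methylpiperidin-1-yl)methyl on a saturated chain carbon, two bonds along the chain from a sulfur. Among the measured compounds shown here, the step from compound 1 to compound 2 concerns only a methyl on the ring that now leaves, and no measured step covers the loss of that ring or the entry of the methoxycarbonyl group; the direction is therefore open and the range wide. Compound 3 is expected at 600 nM, between 150 nM and 3000 nM. This estimate corresponds to an expected step of a 2.8-fold higher number from compound 2 to compound 3 (0.44 log units; beyond the scatter).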

Compound 3, half-maximal inhibitory concentration: 1100 nM
Estimate against measurement, compound 3: 1.8-fold (0.26 log units) below; the range from low to high includes it.
By their numbers in this assay, from the lowest: compounds 2 and 1 (each within the scatter of the next); then compound 3.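

In this assay, methoxycarbonyl in place of (4-methylpiperidin-1-yl)methyl gives a 5.1-fold higher number from compound 2 to compound 3 (0.70 log units; beyond the scatter), and in place of (piperidin-1-yl)methyl it gives a 4.4-fold higher number from compound 1 to compound 3 (0.64 log units; beyond the scatter). Among these compounds, the number at this position therefore responds to replacing the ring-bearing chain end, whereas the methyl on the ring produced no separable step. No available evidence bears on the reason for this shift.

The change removes the ring and its nitrogen, adds methoxycarbonyl and alters the chain at once, so these contributions remain unseparated. A dimethylamino group or a carboxylic acid at the chain end would address this.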